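A few compounds are considered here, and "the series" means these few. Any claim that something is new, unique, unknown or untested is made for them only; others in the source may bear on it.

Working notes on the acetoxy coumarin series. Compound 1 `CC(=O)Oc1cccc2cc(-c3ccccc3)c(=O)oc12` in an assay on CHO cells for displacement of a labelled ligand from adenosine receptor A1 (Homo sapiens), read by radioligand binding (on this read-out higher numbers stand for weaker inhibition and lower numbers for stronger inhibition), gives 6930 nM. Compound 2 `CC(=O)Oc1ccc2cc(-c3ccccc3)c(=O)oc2c1OC(C)=O` carries acetoxy in place of hydrogen on an aromatic carbon and in this assay gives 8560 nM, so the step is a 1.2-fold higher number from compound 1 to compound 2 (0.09 log units; within the scatter). Compound 3 `CC(=O)Oc1ccc(-c2cc3cccc(OC(C)=O)c3oc2=O)cc1OC(C)=O` in this assay reaches only a limit, > 100000 nM; this is the limit of > 100000 nM in this assay, at which 1 of the 3 values shown sits. The difference between the core of compound 1 and the core of compound 3 is not broken down here. Compound 4 `CC(=O)Oc1ccc(-c2cc3ccc(OC(C)=O)c(OC(C)=O)c3oc2=O)cc1OC(C)=O` differs from compound 3 by acetoxy in place of hydrogen on an aromatic carbon, the same change as from compound 1 to compound 2, at a place described in the same words. Because a 1.2-fold higher number from compound 1 to compound 2 (0.09 log units; within the scatter) sits within the scatter, the step to compound 4 is expected to be a step that the limit leaves unreadable from compound 3 to compound 4, and compound 4 is expected to remain at the limit. Compound 4 is therefore estimated at 150000 nM, between 50000 nM and 500000 nM.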

Compound 4, inhibition constant: > 100000 nM
Compound 4 ended at the assay's limit; the forecaster's own chance of this, stated with the estimate: 85%; the middle value is on the limit's open side.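

Compound 3 and compound 4 both stand at a limit in this assay, so no new step can be read: the limit of > 100000 nM in this assay, at which 2 of the 4 values shown sit.

Left open is whether acetoxy in place of hydrogen on an aromatic carbon changes anything on the core of compound 3.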